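A few compounds are considered here, and "the series" means these few. Any claim that something is new, unique, unknown or untested is made for them only; others in the source may bear on it.

Measured so far in a physicochemical assay for lipophilicity, using the shake flask method, in phosphate buffer, measured as octanol-water partition, with a stated time of 24 h, at pH 7.4, tested at 100 uM; a higher number here means a more lipophilic compound, a lower number a more polar compound:
compound 1 `CCOc1cc(C)c(-c2cccc(COc3ccc(OCC(=O)O)c(F)c3)c2)c(C)c1` gives 3.48
compound 2 `CC(=O)N(CC(=O)O)c1ccc(OCc2cccc(-c3c(C)cc(OCCCS(C)(=O)=O)cc3C)c2)cc1` gives "not determined" (no result reported)

Among the compounds with values here, compound 1 holds the only number so far. Compound 2 has no result reported, so compound 1 cannot yet be ranked against anything. Compound 3 `COc1cc(C)c(-c2cccc(COc3ccc(OCC(=O)O)c(F)c3)c2)c(C)c1` has not been measured and keeps the core of compound 1 with a single change, hydrogen in place of methyl on a saturated chain carbon bound to an oxygen on an aromatic ring, which reads as ethoxy to methoxy. Within the data shown here, no measured pair shows a single change, so the expectation rests on this structural change alone. A small downward move close to the usual scatter is expected, estimated as a number 0.33 log units lower from compound 1 to compound 3 (beyond the scatter) in this assay. The estimated value for compound 3 is 3.15, with an expected range of 2.8 to 3.45.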

Compound 3, distribution coefficient: 3.2
Beside the measured number, compound 3's estimate is 0.05 log units below it, within the range that was stated.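

In this assay, within the data shown here, the one pair that differs in a single place gives a number 0.28 log units lower from compound 1 to compound 3 (within the scatter). Ethoxy to methoxy, with hydrogen in place of methyl on a saturated chain carbon bound to an oxygen on an aromatic ring, therefore gives no step that can be told apart from repeat-measurement noise on the core of compound 1. Nothing measured here bears on a cause for this result.

The compounds shown leave open whether a longer chain such as butoxy, or an amine in place of the ethoxy group, would give a step beyond the scatter in this assay. Among these compounds, they also leave open whether this same change reads alike on any other core, as this pair is the only example of it.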